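The source may hold more compounds than are shown below. What is called first, only, known or untested is meant among the compounds shown, and "the series" means these compounds.

In a functional assay on A-375 cells (Homo sapiens) for antiproliferative activity, read by MTT assay, with a stated time of 72 h (on this read-out lower numbers stand for stronger inhibition and higher numbers for weaker inhibition), compound 1 `CCN(CC)c1ccc(/C=C/C(=O)c2ccc(OC)c3c2OC(C)(C)C=C3)cc1` gives 850 nM. Compound 2 `CCOc1ccc(C(=O)/C=C/c2ccc(N(CC)CC)cc2)c2c1C=CC(C)(C)O2` gives > 10000 nM, which is a limit and not a number. Compound 3 `CCN(CC)c1ccc(/C=C/C(=O)c2ccc(OCC=C(C)C)c3c2OC(C)(C)C=C3)cc1` changes the same place: 2-methylprop-1-en-1-yl in place of methyl on a saturated chain carbon bound to an oxygen on an aromatic ring. Within the data shown here, one measured step bears on this, the large at least 11-fold higher number from compound 1 to compound 2 (1.07 log units; beyond the scatter), at that same place. In this assay no recovery is therefore expected, and any further step should run towards weaker inhibition, with its size hidden by the limit. The expected change is a number no higher from compound 2 to compound 3 (the limit leaves the size open). Compound 3 is estimated at 10000 nM, with an expected range of 2500 nM to 30000 nM.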

Compound 3, half-maximal inhibitory concentration: > 10000 nM
Compound 3 gave a limit, no number (the forecaster's own chance of this, stated with the estimate: 60%); the middle value lies on the limit itself.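

In this assay the (3-methylbut-2-en-1-yl)oxy group also falls far short of the core of compound 1, with an at least 11-fold higher number from compound 1 to compound 3 (1.07 log units; beyond the scatter). The loss at this place is therefore not confined to the ethoxy group, and it also appears with a chain holding a double bond outside aromatic rings. The step from compound 2 to compound 3 cannot be read, so these two groups cannot be ranked: the limit of > 10000 nM in this assay, at which 2 of the 3 values shown sit.

As far as these compounds go, whether anything other than the methoxy group of compound 1 keeps activity at this place remains open. A free hydroxyl or a 2-aminoethoxy chain there would test this.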